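Cyclopentyl to thiophen-3-yl on the core of compound 2

The compounds below may be only part of what the source reports. "The series", "measured", "known", "first", "only" and "open" are said of these compounds alone.

Among the compounds with values here, compound 2 `COC(=O)c1nc(C2CCCC2)n(-c2ccc(C(F)(F)F)cc2)n1` stands at the higher end of the two numbers so far: in a functional assay on NPC-TW01 cells (Homo sapiens) for inhibition, read by MTT assay, with a stated time of 72 h (a higher number here means a weaker inhibitor of growth, a lower number a stronger inhibitor of growth), compound 2 gives 56400 nM, while compound 1 `COC(=O)c1nc(C2CCCC2)n(-c2ccc(F)cc2)n1` gives 10400 nM, the two separated by the step of a 5.4-fold higher number from compound 1 to compound 2 (0.73 log units; beyond the scatter). Compound 3 `COC(=O)c1nc(-c2ccsc2)n(-c2ccc(C(F)(F)F)cc2)n1` differs from compound 2 by thiophen-3-yl in place of cyclopentyl on an aromatic carbon. Within the data shown here, the only measured step alters a different group, so no measured step bears directly on this exchange and its direction is open. The expected step of a 1.4-fold lower number from compound 2 to compound 3 (0.15 log units; within the scatter) is therefore set close to neutral with a wide range. Compound 3 is estimated in this assay at 40000 nM, between 10000 nM and 150000 nM.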

Compound 3, concentration for 50% growth inhibition: 34900 nM
Beside the measured number, compound 3's estimate is 1.1-fold (0.06 log units) above it; measured number inside the range.
By their numbers in this assay, from the lowest: compound 1; then compounds 3 and 2 (each within the scatter of the next).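

This position, on an aromatic carbon between two ring nitrogen atoms, accepts thiophen-3-yl in place of cyclopentyl in this assay, with a 1.6-fold lower number from compound 2 to compound 3 (0.21 log units; within the scatter). A five-membered non-aromatic ring of carbon only and a five-membered aromatic ring with sulfur are therefore not told apart here when trifluoromethyl is held constant. Nothing available gives a reason for this result. As far as these compounds go, whether thiophen-3-yl reads the same alongside fluoro remains open. Also open, from the compounds shown here alone, is how a phenyl ring, an amine or a longer carbon chain would read at this position.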